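Aryl-for-alkyl exchange on the core, cytotoxicity read-out

The compounds below may be only part of what the source reports. "The series", "measured", "known", "first", "only" and "open" are said of these compounds alone.

Measured so far:
compound 1 `COc1ccc(-c2ccc3c(NCCCNCc4cccc(OC)c4O)ccnc3c2)cc1`: 1600 nM
compound 2 `CCC(CC)c1ccc2c(NCCCNCc3cc(F)ccc3OC)ccnc2c1`: 7860 nM

In an ADME assay on HepG2 cells (Homo sapiens) for cytotoxicity, read by luminescence, CellTiter-Glo and ATP content, with a stated time of 72 h (on this read-out higher numbers stand for an effect only at larger amounts of compound and lower numbers for an effect already at smaller amounts), compound 1 gives 1600 nM and compound 2 gives 7860 nM. Compound 2 stands at the highest of the two numbers; the gap to compound 1 lies beyond the scatter, so compound 2 shows an effect only at larger amounts than compound 1 does. Within the data shown here, no single-point step between the two measured compounds can be drawn, as they differ in more than one place.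

Compound 3 `COc1ccc(-c2ccc3c(NCCCNCc4cc(F)ccc4OC)ccnc3c2)cc1` is not yet measured. It differs from compound 2 by 4-methoxyphenyl in place of pentan-3-yl on an aromatic carbon. With this change compound 3 carries the same 4-methoxyphenyl as compound 1 and otherwise keeps the remainder of compound 2.

For this assay a step toward lower numbers is expected, most likely beyond the scatter, because compound 1 gives 1600 nM with the same 4-methoxyphenyl in place. The expected step is estimated as a 2.6-fold lower number from compound 2 to compound 3 (0.42 log units; beyond the scatter). Compound 3 is therefore estimated at 3000 nM, within a range of 1200 nM to 8000 nM.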

Compound 3, half-maximal effective concentration: 5960 nM
Beside the measured number, compound 3's estimate is 2.0-fold (0.30 log units) below it; the range from low to high includes it.
By their numbers in this assay, from the lowest: compound 1; then compounds 3 and 2 (each within the scatter of the next).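

In this assay the exchange of pentan-3-yl for 4-methoxyphenyl on the aromatic carbon of the shared core (a 1.3-fold lower number from compound 2 to compound 3 (0.12 log units; within the scatter)) stays within the scatter, so this read-out does not separate the two groups at this position, even though a six-membered aromatic ring and a hydrogen-bond acceptor enter with the change. The other exchange, 5-fluoro-2-methoxyphenyl in place of 2-hydroxy-3-methoxyphenyl on the saturated chain carbon bound to an amine nitrogen (a 3.7-fold higher number from compound 1 to compound 3 (0.57 log units; beyond the scatter)), lies beyond the scatter, so among these three compounds the difference in cytotoxicity goes with the aryl group on the chain and not with the group on the core. Nothing at hand gives a reason for either step.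

As far as these compounds go, it remains open whether 2-hydroxy-3-methoxyphenyl on the chain gives the same number with pentan-3-yl on the core as with 4-methoxyphenyl, which would test whether the two places act independently. Also open, from the compounds shown here alone, is how the same aromatic carbon behaves with a quite different group, such as a morpholine, a carboxylic acid or a small methyl.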